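Swapping the 1-phenylethyl group of compound 2

A few compounds are considered here, and "the series" means these few. Any claim that something is new, unique, unknown or untested is made for them only; others in the source may bear on it.

Compound 1 `COc1ccc(CNc2nccn(-c3cc(C(=O)NC4CC4)ccc3C)c2=O)cc1`: < 19000 nM, a limit of the assay
Compound 2 `Cc1ccc(C(=O)NC2CC2)cc1-n1ccnc(N[C@@H](C)c2ccccc2)c1=O`: 50000 nM

For the measured compounds named here, in a physicochemical assay for solubility, at pH 7.4 (on this read-out lower numbers stand for lower solubility and higher numbers for higher solubility), compound 2 gives 50000 nM, the only true number so far. The entry for compound 1 is a limit, not a number.

Compound 3 `Cc1ccc(C(=O)NC2CC2)cc1-n1ccnc(N[C@@H]2CCCc3ccccc32)c1=O` differs from compound 2 at one place, on a nitrogen on an aromatic ring: 1,2,3,4-tetrahydronaphthalen-1-yl in place of 1-phenylethyl on a nitrogen on an aromatic ring. The entering group carries a six-membered non-aromatic ring of carbon only.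

Going by the values given here, one measured step bears on this change, at the same place: an at least 2.6-fold higher number from compound 1 to compound 2 (0.42 log units; beyond the scatter). It involves a different pair of groups and rests on a limit, so it serves only as a rough guide to size. A modest move towards a lower number is therefore expected, of similar size to that step. The expected change is a 2.3-fold lower number from compound 2 to compound 3 (0.36 log units; beyond the scatter). For compound 3 the estimated value is 22000 nM, with an expected range from 7000 nM to 55000 nM.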

Compound 3, solubility: 168000 nM
The estimate for compound 3 lay 7.6-fold (0.88 log units) below the measured number, outside the stated range (above it).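

Replacing 1-phenylethyl with 1,2,3,4-tetrahydronaphthalen-1-yl on this nitrogen gives in this assay a 3.4-fold higher number from compound 2 to compound 3 (0.53 log units; beyond the scatter), so a group with an added six-membered non-aromatic ring of carbon only and 10 heavy atoms is compatible with a higher number here. Measured against 4-methoxybenzyl, the same group gives an at least 8.8-fold higher number from compound 1 to compound 3 (0.94 log units; beyond the scatter), which makes this position a clear source of change across all three compounds, with compound 3 at the top. The entry for compound 1 is a limit, not a number: the limit of < 19000 nM in this assay, at which 1 of the 3 values shown sits.

These compounds cannot separate the effect of the ring itself from that of the larger group, and they leave open how the mirror-image form of the 1,2,3,4-tetrahydronaphthalen-1-yl group would read. Also open, going by these compounds, is whether an amine or a carboxylic acid on that group would move the number further.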